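The compounds below may be only part of what the source reports. "The series", "measured", "known", "first", "only" and "open" are said of these compounds alone.

Compound 1, with the structure `O=C(c1ccc(Cl)cc1)N1CCC(NS(=O)(=O)c2cc(S(=O)(=O)c3ccccc3)ccc2C(F)(F)F)CC1`, is one of three compounds built on a shared core that differ only in the group on an amine nitrogen in a ring. In an assay on U2OS cells for inhibition of secreted frizzled-related protein 1 (Homo sapiens), read by a luciferase reporter, with a stated time of 18 h (on this read-out lower numbers stand for an effect already at smaller amounts and higher numbers for an effect only at larger amounts of compound), compound 1 gives 1800 nM, the highest of the three numbers. Compound 2, `O=C(O)c1ccc(N2CCC(NS(=O)(=O)c3cc(S(=O)(=O)c4ccccc4)ccc3C(F)(F)F)CC2)cc1`, gives 230 nM, and compound 3, `CC(C)(O)CCN1CCC(NS(=O)(=O)c2cc(S(=O)(=O)c3ccccc3)ccc2C(F)(F)F)CC1`, gives 630 nM. The two measured steps away from compound 1 both run downward: a 7.8-fold lower number from compound 1 to compound 2 (0.89 log units; beyond the scatter) and a 2.9-fold lower number from compound 1 to compound 3 (0.46 log units; beyond the scatter); between the other two, a 2.7-fold higher number from compound 2 to compound 3 (0.44 log units; beyond the scatter).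

Compound 4, `O=C(C1CCNCC1)N1CCC(NS(=O)(=O)c2cc(S(=O)(=O)c3ccccc3)ccc2C(F)(F)F)CC1`, is not yet measured. It differs from compound 1 in one place: piperidin-4-yl in place of 4-chlorophenyl on a carbonyl carbon. Unlike compound 2 and compound 3, compound 4 keeps the carbonyl on the ring nitrogen, so the two measured steps bear on it only in part. Still, in both cases an exchange of the 4-chlorophenyl-containing group for a group carrying a hydrogen-bond donor and acceptor gave a modestly lower number. A modest step in the same direction, beyond the scatter but smaller than the step to compound 2, is therefore expected, which is a 3.0-fold lower number from compound 1 to compound 4 (0.48 log units; beyond the scatter). The estimated value for compound 4 is 600 nM, expected to fall between 200 nM and 1800 nM.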

Compound 4, half-maximal effective concentration: 150 nM
Compound 4: the middle estimate sits 4.0-fold (0.60 log units) above what was measured; the measured number lies below the stated range.
By their numbers in this assay, from the lowest: compounds 4 and 2 (each within the scatter of the next); then compound 3; then compound 1.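

Keeping the carbonyl on the ring nitrogen and changing only the group on it, a 12-fold lower number from compound 1 to compound 4 (1.08 log units; beyond the scatter) in this assay is the largest step in this set, so the carbonyl itself does not have to go for the number to fall, as compounds 2 and 3, which both lack it, could not show. The (piperidin-4-yl)carbonyl group also stands apart from 3-hydroxy-3-methylbutyl, with a 4.2-fold lower number from compound 3 to compound 4 (0.62 log units; beyond the scatter) beyond the scatter, whereas a 1.5-fold lower number from compound 2 to compound 4 (0.19 log units; within the scatter) within the scatter means that it and 4-carboxyphenyl cannot be told apart here, even though these two groups have different structures. No measurement available here explains why this exchange on the carbonyl carbon changes the number so much.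

The compounds shown leave open whether the ring nitrogen of piperidin-4-yl is needed, which cyclohexyl on the same carbonyl carbon, with carbon in place of that nitrogen, would test. They also leave open whether the ring matters at all, or whether an open-chain amine such as 2-aminoethyl on that carbonyl carbon would give a similar number.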